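The compounds below may be only part of what the source reports. "The series", "measured", "known", "first", "only" and "open" are said of these compounds alone.

Working notes on the series. Of the compounds shown here, three have been measured in a functional assay for inhibition, with Homo sapiens as the target; on this read-out higher numbers stand for weaker inhibition and lower numbers for stronger inhibition. Compound 1 `Cc1cc(C)cc(Nc2nccc(-c3ccccn3)n2)c1` gives 100 nM. Compound 2 `CCOC(=O)c1cccc(Nc2nccc(-c3ccccn3)n2)c1` gives 3000 nM. Compound 3 `Cc1cccc(Nc2nccc(-c3ccc(C)o3)n2)c1` gives 2000 nM. Among these three numbers compound 3 holds the second highest; its nearest neighbour is compound 2, whose value lies within the usual scatter of compound 3's, so no order between these two is claimed. Its furthest neighbour is compound 1, whose value lies well beyond the scatter from that of compound 3.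

The next compound, compound 4 `Cc1cccc(Nc2nccc(-c3ccccn3)n2)c1`, has not yet been measured in this assay. Compared with compound 3 the change is pyridin-2-yl in place of 5-methylfuran-2-yl on an aromatic carbon. For the measured compounds named here, no step between measured compounds matches this exchange, so the expectation rests on what the measured values show. Compound 1 also carries pyridin-2-yl and gives 100 nM in this assay, whereas compound 3 with its 5-methylfuran-2-yl gives 2000 nM; on that basis a downward step, beyond the scatter, is expected for compound 4. The estimated step from compound 3 to compound 4 is an 8.0-fold lower number from compound 3 to compound 4 (0.90 log units; beyond the scatter). Compound 4 is therefore expected to give about 250 nM in this assay, with a likely range from 60 nM to 1000 nM.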

Compound 4, half-maximal inhibitory concentration: 700 nM
For compound 4 the middle estimate is 2.8-fold (0.45 log units) below the measured one; the range from low to high includes it.
By their numbers in this assay, from the lowest: compound 1; then compound 4; then compounds 3 and 2 (each within the scatter of the next).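

Working from this assay, pyridin-2-yl in place of 5-methylfuran-2-yl on an aromatic carbon gives a 2.9-fold lower number from compound 3 to compound 4 (0.46 log units; beyond the scatter), which shows on a single matched pair that this position responds to an exchange between two groups with equal heavy-atom and hydrogen-bond acceptor counts, differing in ring size and hetero atom. With pyridin-2-yl held in place, the other substituted ring also responds to single changes: methyl in place of ethoxycarbonyl gives a 4.3-fold lower number from compound 2 to compound 4 (0.63 log units; beyond the scatter), and hydrogen in place of the second methyl of compound 1 gives a 7.0-fold higher number from compound 1 to compound 4 (0.85 log units; beyond the scatter), so compound 4 links all three earlier compounds by single changes. The compounds shown offer no independent measurement that would account for any of these steps.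

On these data alone, it remains open whether the step between pyridin-2-yl and 5-methylfuran-2-yl keeps its direction and size on the core of compound 1 or compound 2, as it has been read on one background only. Also open, as far as these compounds go, is how this position would respond to furan-2-yl without its methyl or to pyridin-3-yl, and how the other ring would respond to an amine or a carboxylic acid.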